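A few compounds are considered here, and "the series" means these few. Any claim that something is new, unique, unknown or untested is made for them only; others in the source may bear on it.

Compound 1 `Cc1ccc(S(=O)(=O)N[C@@H](CC(=O)NC(C)(C)C)C(=O)NCCNC(=O)c2cccc(O)c2)cc1`: > 11000 nM
Compound 2 `Cc1ccc(S(=O)(=O)N[C@@H](CC(=O)NC(C)(C)C)C(=O)NCCNC(=O)c2c(O)cccc2F)cc1`: > 11000 nM
Compound 3 `COc1cccc(C(=O)NCCNC(=O)[C@H](CC(=O)NC(C)(C)C)NS(=O)(=O)c2ccc(C)cc2)c1`: > 11000 nM

In an ADME assay on HepG2 cells (Homo sapiens) for cytotoxicity (a lower number here means that less compound is needed, a higher number that more compound is needed for the effect), compound 3 gives > 11000 nM, which is a limit of the assay and not a number. It has no rank among the measured compounds, since the whole set stands at the limit of > 11000 nM in this assay, at which 3 of the 3 values shown sit.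

Going on to compound 4 `Cc1ccc(S(=O)(=O)N[C@@H](CC(=O)NC(C)(C)C)C(=O)NCCNC(=O)c2ccccc2F)cc1` puts 2-fluorophenyl in place of 3-methoxyphenyl on a carbonyl carbon. The closest measured change alters the group at that same place: a step that the two limits leave unreadable from compound 2 to compound 3. The other two measured changes also concern this group: a step that the two limits leave unreadable from compound 1 to compound 2 and a step that the two limits leave unreadable from compound 1 to compound 3. None of the three has a readable size, so they offer no direction to carry over. Compound 1, compound 2 and compound 3 all reach the same limit despite their different groups, and compound 4 is expected to reach it as well. In this assay, the expected result is a step that the limit leaves unreadable from compound 3 to compound 4, with no change beyond the scatter. The estimate for compound 4 is 15000 nM, with an expected range from 11000 nM to 30000 nM.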

Compound 4, half-maximal effective concentration: > 11000 nM
Compound 4: no number, only a limit; the forecaster's own chance of this, stated with the estimate: 90%; the middle value lies beyond the limit too.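

Compound 4 gives > 11000 nM, a limit of the assay and not a number, so its steps from compound 1, compound 2 and compound 3 cannot be read. The compounds shown leave open what concentration each needs for the effect in this assay, and whether the groups on the carbonyl carbon differ at all: the limit of > 11000 nM in this assay, at which 4 of the 4 values shown sit.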